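Extending the ether chain of a weak nicotinic ligand

This account rests on a few compounds, and the source may have more. Where it says the series, first, only, none or still open, it means among the compounds named here.

Measured compounds:
compound 1, `CN1CC[C@@H]2CC[C@H](OCc3ccccc3)C[C@@H]21`, 100000 nM
compound 2, `CCO[C@H]1CC=C2CCN(C)[C@H]2C1`, 300000 nM

For the measured compounds named here, in an assay on HEK293 cells for displacement of a labelled ligand from Neuronal acetylcholine receptor; alpha4/beta2 (Rattus norvegicus), with a stated time of 4 h (a higher number here means a weaker inhibitor, a lower number a stronger inhibitor), compound 2 stands at the highest of the two numbers; compound 1, the only neighbour, sits lower by a gap beyond the usual scatter. Compound 3, `COCCO[C@H]1CC=C2CCN(C)[C@H]2C1`, differs from compound 2 by methoxy in place of hydrogen on a saturated chain carbon, two bonds along the chain from an oxygen on a saturated carbon. Going by the values given here, no measured pair shows a change of this kind, so the expected step from compound 2 to compound 3 is a 1.5-fold lower number from compound 2 to compound 3 (0.18 log units; within the scatter), not beyond the scatter. Compound 3 is therefore estimated at 200000 nM, with a range from 60000 nM to 700000 nM.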

Compound 3, inhibition constant: > 300000 nM
Compound 3: a limit, no number; the forecaster's own chance of this, stated with the estimate: 35%; at least 1.5-fold (0.17 log units) between middle value and limit.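

In this assay compound 3 gives > 300000 nM, which is a limit of the assay and not a number. Going from ethoxy to 2-methoxyethoxy therefore brings no measurable gain in binding, with a number no lower from compound 2 to compound 3 (the limit leaves the size open). The step gives a direction only, and its size cannot be read: the limit of > 300000 nM in this assay, at which 1 of the 3 values shown sits.

Going by these compounds, how far compound 3 actually lies from compound 2 stays open. So does whether an amine or a carboxylic acid in place of the methoxy, or a longer chain, would lower the number in this assay.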